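Series notes: deleting the side chain of compound 3

The source may report more compounds than this note shows. Statements on the series, on what has been measured and on what is new or still open speak of the compounds shown alone.

Measured in a functional assay (aorta) for antagonist activity, with Oryctolagus cuniculus as the target; on this read-out higher numbers stand for weaker inhibition and lower numbers for stronger inhibition:
compound 1 `CCCCc1ccc(CNCc2ccccc2)c(=O)n1Cc1ccc(-c2ccccc2-c2nn[nH]n2)cc1` — 1 nM
compound 2 `CCCCc1ccc(CNC(C)=O)c(=O)n1Cc1ccc(-c2ccccc2-c2nn[nH]n2)cc1` — 3 nM
compound 3 `CCCCc1ccc(CNS(=O)(=O)c2ccc(C)cc2)c(=O)n1Cc1ccc(-c2ccccc2-c2nn[nH]n2)cc1` — 9 nM

Compound 3 stands highest of the three numbers: a 3.0-fold higher number from compound 2 to compound 3 (0.48 log units; beyond the scatter) and a 9.0-fold higher number from compound 1 to compound 3 (0.95 log units; beyond the scatter). The remaining step, a 3.0-fold higher number from compound 1 to compound 2 (0.48 log units; beyond the scatter), separates the other two.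

Compound 4 `CCCCc1cccc(=O)n1Cc1ccc(-c2ccccc2-c2nn[nH]n2)cc1` differs from compound 3 in one place: hydrogen in place of (((4-methylphenyl)sulfonyl)amino)methyl on an aromatic carbon. Among the measured compounds shown here, no measured step removes this side chain; the three measured steps only exchange the group on its amine nitrogen, and each of those exchanges moved the number modestly, all beyond the scatter. Taking away the whole chain is a larger change than any of them, and every exchange so far in this assay raised the number from compound 1 onward, so a further rise is expected rather than a fall, though its size is uncertain. For compound 4 the expected step is a 4.4-fold higher number from compound 3 to compound 4 (0.65 log units; beyond the scatter). Compound 4 is estimated at 40 nM in this assay, with a range from 6 nM to 300 nM.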

Compound 4, half-maximal inhibitory concentration: 4 nM
Compound 4: middle estimate off by 10-fold (1.00 log units), on the high side; the whole stated range lies above it.
By their numbers in this assay, from the lowest: compound 1; then compounds 2 and 4 (each within the scatter of the next); then compound 3.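

In this assay this position does not need a side chain to give a low number: hydrogen in place of (((4-methylphenyl)sulfonyl)amino)methyl gives a 2.3-fold lower number from compound 3 to compound 4 (0.35 log units; beyond the scatter) and so shows that this chain does not add to the activity of the core. The other two chains part ways, since hydrogen in place of acetamidomethyl gives a 1.3-fold higher number from compound 2 to compound 4 (0.12 log units; within the scatter) with no change beyond the scatter, whereas hydrogen in place of (benzylamino)methyl gives a 4.0-fold higher number from compound 1 to compound 4 (0.60 log units; beyond the scatter) and leaves (benzylamino)methyl as the only one of the three chains that improves on hydrogen. Nothing available explains why the deletion moves the number in opposite directions across these chains.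

Open, as far as these compounds go, is whether a free aminomethyl group or a plain methyl at this position would stand with hydrogen or with (benzylamino)methyl. Also open, from the compounds shown here alone, is whether a longer chain between the amine nitrogen and the phenyl ring would lower the number further.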